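This account rests on a few compounds, and the source may have more. Where it says the series, first, only, none or still open, it means among the compounds named here.

Compound 1 `COc1cc(-c2nn(-c3cccc(NC(=O)c4cccc(C(F)(F)F)c4)c3)cc2-c2ccncc2)ccc1Cl`: 560 nM
Compound 2 `COc1cc(-c2nn(-c3cccc(NC(=O)Nc4ccc(Cl)c(C(F)(F)F)c4)c3)cc2-c2ccncc2)ccc1Cl`: 500 nM
Compound 3 `COc1cc(-c2nn(-c3cccc(NC(=O)c4ccccc4)c3)cc2-c2ccncc2)ccc1Cl`: 320 nM

These three compounds were tested in a functional assay on HOP-92 cells (Homo sapiens) for inhibition, read by sulforhodamine B assay, with a stated time of 48 h; a higher number here means a weaker inhibitor, a lower number a stronger inhibitor. Compound 2 has the second highest of the three numbers; its nearest neighbour is compound 1, with the step of a 1.1-fold lower number from compound 1 to compound 2 (0.05 log units; within the scatter), and its furthest is compound 3, with the step of a 1.6-fold lower number from compound 2 to compound 3 (0.19 log units; within the scatter). Both steps lie within the scatter, so no ordering among the three can be claimed. The third measured step, a 1.8-fold lower number from compound 1 to compound 3 (0.24 log units; within the scatter), is likewise within the scatter. Compound 4 `O=C(Nc1cccc(-n2cc(-c3ccncc3)c(-c3ccc(Cl)c(O)c3)n2)c1)Nc1ccc(Cl)c(C(F)(F)F)c1` has not yet been measured. It differs from compound 2 in one place: hydrogen in place of methyl on an oxygen on an aromatic ring. Among the measured compounds shown here, none of the measured steps touches this oxygen; all three change the group on the carbonyl carbon, and each stayed within the scatter. For the measured compounds named here, there is therefore no measured step that bears directly on the change from compound 2 to compound 4, and no basis for expecting a move beyond the scatter. The expected step from compound 2 to compound 4 is no change at the digits printed from compound 2 to compound 4 (within the scatter). Compound 4 is estimated at 500 nM, with a range from 200 nM to 1300 nM.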

Compound 4, half-maximal inhibitory concentration: 380 nM
Beside the measured number, compound 4's estimate is 1.3-fold (0.12 log units) above it, and the stated range covers the measured number.
By their numbers in this assay, from the lowest: compounds 3, 4, 2 and 1 (each within the scatter of the next).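

Compound 4 brings the first change away from the group on the carbonyl carbon: in this assay, replacing methoxy with hydroxy on the aromatic ring gives a 1.3-fold lower number from compound 2 to compound 4 (0.12 log units; within the scatter). Losing this methyl, a single carbon, therefore leaves the number within the scatter, so this oxygen can carry a hydrogen instead of a methyl without a measurable shift in this cell assay. No measurement available here offers an explanation for this result.

The compounds shown leave open whether a larger group on this oxygen, such as ethyl or a longer chain, or an amine in place of the hydroxy, would also stay within the scatter. Going by these compounds, it is also open whether the same swap would read alike on compound 1 and compound 3, which carry different groups on the carbonyl carbon.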